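Chloro to methoxy on the core of compound 1

The source may report more compounds than this note shows. Statements on the series, on what has been measured and on what is new or still open speak of the compounds shown alone.

Measured so far in a functional assay on MCF7 cells (Homo sapiens) for antiproliferative activity, read by MTT assay, with a stated time of 48 h (a lower number here means a stronger inhibitor, a higher number a weaker inhibitor), for three compounds:
compound 1 `COc1ccc(-c2nc(C)c(C(=O)CSc3nc(N)c(C#N)c(-c4ccc(Cl)cc4)n3)s2)cc1` gives 11300 nM here
compound 2 `COc1ccc(-c2nc(C)c(C(=O)CSc3nc(-c4ccc(OC)c(OC)c4)c(C#N)c(=O)[nH]3)s2)cc1` gives 24000 nM here
compound 3 `Cc1nc(-c2ccccc2)sc1C(=O)CSc1nc(N)c(C#N)c(-c2ccc(Cl)cc2)n1` gives 20200 nM here

Compound 1 stands within the scatter of compound 3 and just beyond the scatter from compound 2. Compound 4 `COc1ccc(-c2nc(C)c(C(=O)CSc3nc(N)c(C#N)c(-c4ccc(OC)cc4)n3)s2)cc1` has not yet been measured. It carries methoxy in place of chloro on an aromatic carbon, para to a large group, so that 4-chlorophenyl becomes 4-methoxyphenyl (methoxy in place of chloro on an aromatic carbon) on the core of compound 1. Going by the values given here, only one measured step bears on this, and only loosely: a 1.8-fold higher number from compound 1 to compound 3 (0.25 log units; within the scatter) with hydrogen in place of methoxy on an aromatic carbon, at another place in the molecule, and it stays within the scatter. Compound 2 at 24000 nM differs from compound 1 in more than one place and gives no clean reading. The expected outcome in this assay is a 1.2-fold higher number from compound 1 to compound 4 (0.06 log units; within the scatter) and thus no step beyond the scatter. For compound 4 the estimated value is 13000 nM with an expected range from 6000 nM to 28000 nM in this read-out.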

Compound 4, half-maximal inhibitory concentration: 24300 nM
Estimate against measurement, compound 4: 1.9-fold (0.27 log units) below; the range from low to high includes it.
By their numbers in this assay, from the lowest: compounds 1, 3, 2 and 4 (each within the scatter of the next, the first and the last beyond it).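

In this assay, putting methoxy in place of chloro, so that 4-chlorophenyl becomes 4-methoxyphenyl, gives a 2.2-fold higher number from compound 1 to compound 4 (0.33 log units; beyond the scatter). Going by these compounds alone, this is the first single-place change on the core of compound 1 to lie beyond the scatter, whereas the earlier step, a 1.8-fold higher number from compound 1 to compound 3 (0.25 log units; within the scatter), stayed within it, so this position does respond, though modestly, and the change leads to a weaker inhibitor. Nothing among the data shown gives a measured reason for this step.

As far as these compounds go, with only chloro and methoxy seen at this position, it remains open whether a fluoro, a methyl or an amine there would track with either of them. From the compounds shown here alone, it is also open whether the same change would give a step of similar size on the core of compound 3.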